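Working notes: replacing the aryl group on the carbonyl

This account rests on a few compounds, and the source may have more. Where it says the series, first, only, none or still open, it means among the compounds named here.

- compound 1 `Cc1ccc(C(=O)Nc2nnc(-c3ccc(O)c(O)c3)s2)cc1`: 67100 nM
- compound 2 `O=C(Nc1nnc(-c2ccc(O)c(O)c2)s1)c1ccc(Cl)cc1`: 47300 nM

In a functional assay on HeLa cells (Homo sapiens) for cytotoxicity, read by MTT assay, with a stated time of 72 h (a higher number here means a weaker inhibitor, a lower number a stronger inhibitor), compound 2 gives 47300 nM, level with compound 1 within the scatter. Compound 3 `CC(=O)Nc1nnc(-c2ccc(O)c(O)c2)s1` has not been measured. Its structure differs from that of compound 2 as follows: methyl in place of 4-chlorophenyl on a carbonyl carbon. This is methyl in place of 4-chlorophenyl on a carbonyl carbon. Among the compounds with values here, the only measured step is a 1.4-fold lower number from compound 1 to compound 2 (0.15 log units; within the scatter), chloro in place of methyl on an aromatic carbon. That step bears only loosely, since the aromatic ring stays in both compounds, and no measurement shows what removing it does. A modest move to a higher number in this assay is therefore expected, though with little confidence in its size or direction. The expected change is a 1.8-fold higher number from compound 2 to compound 3 (0.25 log units; within the scatter). The estimate for compound 3 is 85000 nM, with an expected range of 35000 nM to 220000 nM.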

Compound 3, half-maximal inhibitory concentration: 125000 nM
Compound 3: the middle estimate sits 1.5-fold (0.17 log units) below what was measured, within the range that was stated.
By their numbers in this assay, from the lowest: compounds 2, 1 and 3 (each within the scatter of the next, the first and the last beyond it).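

In this assay, the aromatic ring on the carbonyl carbon can now be judged by its removal, which the earlier pair could not show: methyl in place of 4-chlorophenyl gives a 2.6-fold higher number from compound 2 to compound 3 (0.42 log units; beyond the scatter), a modest step. Methyl in place of 4-methylphenyl at the same carbon gives a 1.9-fold higher number from compound 1 to compound 3 (0.27 log units; within the scatter), so the effect of losing the ring is clear against the 4-chlorophenyl compound only, and the two aryl groups do not yield one shared step. Nothing at hand explains this difference between the two steps.

Still open, as far as these compounds go, is whether a longer chain such as butyl, in place of methyl, would follow compound 3 or the aryl compounds. Also open, from the compounds shown here alone, is what an amine or a carboxylic acid on the carbonyl-bound aromatic ring would do to the number.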